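A few compounds are considered here, and "the series" means these few. Any claim that something is new, unique, unknown or untested is made for them only; others in the source may bear on it.

Measured in an ADME assay on microsomes from liver (Homo sapiens) for metabolic stability, using NADPH, with a stated time of 10 min; on this read-out lower numbers stand for a less stable compound and higher numbers for a more stable compound:
- compound 1 `NC/C=C/CN(C[C@H]1Cc2ncccc2CN1)[C@H]1CCCc2cccnc21`: 85%
- compound 2 `CN(C)CCCCN(C[C@H]1Cc2ncccc2CN1)[C@H]1CCCc2cccnc21`: 100%

Of these two compounds, compound 2 stands highest, at 100%. The next structure is compound 3 `CCN(CC)CCCCN(C[C@H]1Cc2ncccc2CN1)[C@H]1CCCc2cccnc21`, which carries diethylamino in place of dimethylamino on a saturated chain carbon, four bonds along the chain from an amine nitrogen.

For the measured compounds named here, only one measured step bears on this change, and only indirectly: a number 15 percentage points higher from compound 1 to compound 2 (beyond the scatter). Going by the values given here, that step swapped a whole group on the same chain and stayed modest, whereas the new change alters only the end of the group, and no measured pair tests that swap directly. A similar or smaller step is therefore expected in this assay, and with compound 2 at 100% it could hardly point upward. The expected step is a number 8 percentage points lower from compound 2 to compound 3 (within the scatter), likely within the scatter. For compound 3 the estimated value is 92%, with an expected range of 74% to 100%.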

Compound 3, percent of the compound remaining: 80%
Compound 3: the middle estimate sits 12 percentage points above what was measured, and the stated range covers the measured number.
By their numbers in this assay, from the lowest: compounds 3 and 1 (each within the scatter of the next); then compound 2.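

In this assay the chain stays the same and only its end changes, and diethylamino in place of dimethylamino still gives a number 20 percentage points lower from compound 2 to compound 3 (beyond the scatter) on this read-out. So, for this pair, a small edit at the far end of the chain is enough to move the number, which the earlier step could not show since it replaced the whole group. The other new step, a number 5 percentage points lower from compound 1 to compound 3 (within the scatter), means that 3-(diethylamino)propyl and 3-aminoprop-1-en-1-yl cannot be told apart here, and nothing available explains either result.

On these data alone, it remains open whether a primary amine or a ring amine such as pyrrolidine or morpholine at the end of the same chain would stay nearer compound 2 or compound 3. A longer or shorter chain carrying dimethylamino also remains untested in the compounds shown here.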